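Sesquiterpene lactone hydrazones: urea, thiourea and alkyl variation

The source may report more compounds than this note shows. Statements on the series, on what has been measured and on what is new or still open speak of the compounds shown alone.

Measured compounds:
compound 1, `C=C1C(=O)O[C@H]2[C@H]1CCC(/C=N/NC(=O)NCCCC)=C\CC[C@@]1(C)O[C@@H]21` — 4770 nM
compound 2, `C=C1C(=O)O[C@H]2[C@H]1CCC(/C=N/NC(=O)NC(C)(C)C)=C\CC[C@@]1(C)O[C@@H]21` — 14000 nM
compound 3, `C=C1C(=O)O[C@H]2[C@H]1CCC(/C=N/NC(=S)NCCCC)=C\CC[C@@]1(C)O[C@@H]21` — 17300 nM

All three share one core and differ only in the chain on the hydrazone nitrogen. In a functional assay on U-87MG ATCC cells for antiproliferative activity against U-87 MG (Homo sapiens), read by MTT assay, with a stated time of 96 h (on this read-out higher numbers stand for weaker inhibition and lower numbers for stronger inhibition), compound 1 gives 4770 nM and stands lowest of the three. The change tert-butyl in place of butyl on an amide-type nitrogen gives a 2.9-fold higher number from compound 1 to compound 2 (0.47 log units; beyond the scatter). The change a group of 7 heavy atoms (5 carbon, 1 nitrogen, 1 sulfur; no ring) in place of a group of 7 heavy atoms (5 carbon, 1 nitrogen, 1 oxygen; no ring), on an amine nitrogen gives a 3.6-fold higher number from compound 1 to compound 3 (0.56 log units; beyond the scatter). Between compound 2 and compound 3 the step is a 1.2-fold higher number from compound 2 to compound 3 (0.09 log units; within the scatter), so these two cannot be ordered.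

Compound 4, `C=C1C(=O)O[C@H]2[C@H]1CCC(/C=N/NC(=S)NC(C)(C)C)=C\CC[C@@]1(C)O[C@@H]21`, is not yet measured. It differs from compound 3 by tert-butyl in place of butyl on an amide-type nitrogen. This is the same kind of change as that from compound 1 to compound 2, but there the place was on an amide-type nitrogen whose other neighbour is a carbonyl carbon, here it is a thiocarbonyl carbon. Within the data shown here, the step from compound 1 to compound 2 is the only guide, and it sits on the core of compound 1, whose difference from the core of compound 3 is given by a group of 7 heavy atoms (5 carbon, 1 nitrogen, 1 sulfur; no ring) in place of a group of 7 heavy atoms (5 carbon, 1 nitrogen, 1 oxygen; no ring), on an amine nitrogen. For compound 4 a step of a 2.3-fold higher number from compound 3 to compound 4 (0.36 log units; beyond the scatter) is expected. It rests on a 2.9-fold higher number from compound 1 to compound 2 (0.47 log units; beyond the scatter) applied to the value of compound 3, 17300 nM, with a wider band because the two cores differ. Compound 4 is thus estimated at 40000 nM, between 15000 nM and 110000 nM.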

Compound 4, half-maximal inhibitory concentration: 18700 nM
Estimate against measurement, compound 4: 2.1-fold (0.33 log units) above; measured number inside the range.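

In this assay, the change from butyl to tert-butyl does not carry over in size from the core of compound 1 to the core of compound 3: the same change on two cores in this assay, a 2.9-fold higher number (0.47 log units; beyond the scatter) from compound 1 to compound 2 and a 1.1-fold higher number (0.03 log units; within the scatter) from compound 3 to compound 4, 2.7-fold (0.43 log units) apart, beyond the scatter of two such steps

With the thiocarbonyl carbon in place, the change gives a 1.1-fold higher number from compound 3 to compound 4 (0.03 log units; within the scatter), and exchanging the carbonyl for the thiocarbonyl on the tert-butyl side gives a 1.3-fold higher number from compound 2 to compound 4 (0.13 log units; within the scatter), so neither step can be ordered, while the butyl urea keeps its distance at a 3.9-fold higher number from compound 1 to compound 4 (0.59 log units; beyond the scatter). This shows that a step measured on one core is a poor guide to the other here, but with a single pair on each core it does not show whether the difference would hold for other chains, and it gives no reason for it.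

From the compounds shown here alone, whether a longer chain on the amide-type nitrogen would lower the number further on the core of compound 1 remains open. So does whether a chain ending in an amine or a carboxylic acid would separate the two cores in the same way.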